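Replacing a chlorinated ring with a methoxy-bearing one

The compounds below may be only part of what the source reports. "The series", "measured", "known", "first", "only" and "open" are said of these compounds alone.

Three chalcone-type compounds sharing one core have been measured in a functional assay on SW480 cells (Homo sapiens) for cytotoxicity, read by sulforhodamine B assay, with a stated time of 48 h; a higher number here means a weaker inhibitor, a lower number a stronger inhibitor. Compound 1 `COc1ccc(/C=C/C(=O)c2cccc(-c3cccc(F)c3)c2)cc1` gives 4510 nM. Compound 2 `O=C(/C=C/c1cccc(Br)c1)c1cccc(-c2cccc(F)c2)c1` gives 8610 nM. Compound 3 `O=C(/C=C/c1ccc(Cl)cc1)c1cccc(-c2cccc(F)c2)c1` gives 16900 nM, the highest of the three numbers; its nearest neighbour is compound 2, and the gap between them, a 2.0-fold higher number from compound 2 to compound 3 (0.29 log units; within the scatter), is within the scatter, while the gap to compound 1, a 3.7-fold higher number from compound 1 to compound 3 (0.57 log units; beyond the scatter), is beyond it.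

Compound 4 `COc1ccccc1/C=C/C(=O)c1cccc(-c2cccc(F)c2)c1` has not yet been measured in this assay. It differs from compound 3 in one place: 2-methoxyphenyl in place of 4-chlorophenyl on a double-bonded chain carbon bound to a double-bonded chain carbon.

For the measured compounds named here, the step that bears most directly on this change is the one from compound 1 to compound 3, a 3.7-fold higher number from compound 1 to compound 3 (0.57 log units; beyond the scatter), where chloro stood in for methoxy and the number rose modestly. Compound 4 reverses that exchange, though its methoxy sits at a different ring position, which the measured compounds do not cover. The steps of a 1.9-fold higher number from compound 1 to compound 2 (0.28 log units; within the scatter) and a 2.0-fold higher number from compound 2 to compound 3 (0.29 log units; within the scatter) were both within the scatter, so swapping one ring for another has so far moved the number only a little.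

A lower number than compound 3 is therefore expected for compound 4, with the expected step being a 2.6-fold lower number from compound 3 to compound 4 (0.41 log units; beyond the scatter). The estimate for compound 4 in this assay is 6500 nM, with a range from 2500 nM to 17000 nM.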

Compound 4, half-maximal inhibitory concentration: 16600 nM
For compound 4 the middle estimate is 2.6-fold (0.41 log units) below the measured one; low and high end bracket the measured number.
By their numbers in this assay, from the lowest: compounds 1, 2, 4 and 3 (each within the scatter of the next, the first and the last beyond it).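

In this assay, a methoxy group on this ring does not by itself go with a lower number: 2-methoxyphenyl reads the same as 4-chlorophenyl within the scatter (a 1.0-fold lower number from compound 3 to compound 4 (0.01 log units; within the scatter)) and the same as 3-bromophenyl within the scatter (a 1.9-fold higher number from compound 2 to compound 4 (0.29 log units; within the scatter)). For the compounds shown here, the one new step beyond the scatter keeps the methoxy group and changes only its place on the ring, with 2-methoxyphenyl in place of 4-methoxyphenyl (a 3.7-fold higher number from compound 1 to compound 4 (0.57 log units; beyond the scatter)), so at this position the group's place on the ring counts, not just its presence. Nothing at hand explains this difference between the two methoxy-bearing rings.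

The four compounds leave open whether the lower number of the 4-methoxyphenyl compound is specific to methoxy, or whether a hydroxyl or an amine on the ring, in the place the methoxy holds in the 4-methoxyphenyl group, would read the same. They also leave open whether a longer chain on that oxygen, such as ethoxy, would keep the number of the 4-methoxyphenyl compound or lose it.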